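The source may hold more compounds than are shown below. What is called first, only, known or untested is meant among the compounds shown, and "the series" means these compounds.

Working notes on the series

Compound 1 `Nc1nc(Cl)c2ncn(Cc3ccc(CCl)cc3)c2n1`, compound 2 `ClCc1cccc(Cn2cnc3nc(Cl)nc(Cl)c32)c1` and compound 3 `ClCc1ccccc1Cn1cnc2nc(Cl)nc(Cl)c21` share one fused core and differ in how the chlorinated benzyl arm and the core chlorines are arranged. In a functional assay on SN12C cells (Homo sapiens) for cytotoxicity, read by sulforhodamine B assay, with a stated time of 48 h (on this read-out higher numbers stand for lower toxicity in this test and lower numbers for higher toxicity in this test), compound 1 gives 60300 nM. In this assay compound 3 gives 5620 nM. For compound 2 the entry in this assay reads "not determined" (no result reported), so no number is available for it. Of the two numbers available, compound 3 stands at the lower end: the nearest number, that of compound 1, lies well above it, and the gap is beyond the scatter, so compound 3 is the more toxic of the two measured entries.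

Compound 4 `ClCc1ccccc1Cn1cnc2ncnc(Cl)c21` is the next step from compound 3. The change is hydrogen in place of chloro on an aromatic carbon. Going by the values given here, no pair of measured compounds shows this same change, so its size in this assay has no direct precedent in this set. With the chloro removed and nothing larger put in its place, a modest loss of toxicity is expected, of a size that may or may not clear the scatter, rather than a large jump in either direction. For compound 4 the expected number in this assay is 10000 nM, with a range from 3000 nM to 35000 nM. The estimated change from compound 3 to compound 4 in this assay is a 1.8-fold higher number from compound 3 to compound 4 (0.25 log units; within the scatter).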

Compound 4, concentration lethal to 50% of the cells: 42700 nM
Estimate against measurement, compound 4: 4.3-fold (0.63 log units) below; measured number above the stated range.
By their numbers in this assay, from the lowest: compound 3; then compounds 4 and 1 (each within the scatter of the next).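

Removing the chloro from the aromatic carbon between two ring nitrogen atoms, with hydrogen entering in its place, gives a 7.6-fold higher number from compound 3 to compound 4 (0.88 log units; beyond the scatter) in this assay, so toxicity in this test falls measurably with this single change. Going by these compounds alone, this is the first step that isolates one position, as the earlier compounds offered no pair differing in one place; it shows that this chloro, a single heavy atom, matters to the read-out in the setting of compound 3 and that its loss is not a silent edit. The data shown give no independent measurement that would explain the size of this step.

Going by these compounds, whether the effect depends on chlorine specifically or on any group larger than hydrogen remains open, and a fluoro, bromo, methyl or methoxy group at the same carbon would separate those two readings. On these data alone, it is also open whether the step keeps its size when the chloromethyl group sits elsewhere on the benzyl arm, and what replacing the remaining core chloro with hydrogen or a methoxy group would do.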